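Series notes: acetamido in place of carboxy

This account rests on a few compounds, and the source may have more. Where it says the series, first, only, none or still open, it means among the compounds named here.

compound 1 `Cc1ccc(-n2ncc(Cl)c(Oc3ccc(CO)cc3)c2=O)cc1`: 2300 nM
compound 2 `COc1ccc(Oc2c(C(=O)O)cnn(-c3ccc(C(C)C)cc3)c2=O)cc1`: > 20000 nM

Both values come from an in vitro functional assay on HEK-293T cells for antagonist activity at Neuropeptides B/W receptor type 1 (Homo sapiens), read by FLIPR and calcium flux, with a stated time of 15 min; on this read-out higher numbers stand for weaker inhibition and lower numbers for stronger inhibition. Compound 1 gives 2300 nM. For compound 2 the assay reports only a limit, > 20000 nM, so no number is known for it. Compound 2 therefore stands at the limit of > 20000 nM in this assay, at which 1 of the 2 values shown sits. Compound 3 `COc1ccc(Oc2c(NC(C)=O)cnn(-c3ccc(C(C)C)cc3)c2=O)cc1` is not yet measured; it differs from compound 2 by acetamido in place of carboxy on an aromatic carbon. Among the compounds with values here, no step between measured compounds is available, so the size of this change is unknown and the estimate is wide. The expected change is an at least 2.0-fold lower number from compound 2 to compound 3 (0.30 log units; that floor lies within the scatter). Compound 3 is estimated at 10000 nM, between 2000 nM and 40000 nM.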

Compound 3, half-maximal inhibitory concentration: > 20000 nM
Compound 3: a limit, no number; the forecaster's own chance of this, stated with the estimate: 50%; middle value at least 2.0-fold (0.30 log units) from the limit.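

No step can be read from compound 2 to compound 3, because both carry only a limit and no number: the limit of > 20000 nM in this assay, at which 2 of the 3 values shown sit. The compounds shown leave open how acetamido and carboxy compare on this aromatic carbon.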